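This account rests on a few compounds, and the source may have more. Where it says the series, first, only, none or still open, it means among the compounds named here.

Measured compounds and their values:
- compound 1 `Cc1ccc(S(=O)(=O)Nc2ccc(C(=O)/C=C/c3ccccc3)cc2)cc1`: "not active" (no number reported)
- compound 2 `Cc1ccc(/C=C/C(=O)c2ccc(NS(=O)(=O)c3ccc(C)cc3)cc2)cc1`: 49800 nM
- compound 3 `Cc1ccc(S(=O)(=O)Nc2ccc(C(=O)/C=C/c3ccc(Br)cc3)cc2)cc1`: 30300 nM

Three compounds built on the shared core of compound 1 have been tested in a functional assay on HepG2 cells (Homo sapiens) for cytotoxicity, read by sulforhodamine B assay, with a stated time of 48 h; a lower number here means a stronger inhibitor, a higher number a weaker inhibitor. For compound 1 no number was reported in this assay; it was recorded as not active. Compound 2 and compound 3 both gave numbers, and compound 3 carries the lower of the two. The only single-point comparison available is a 1.6-fold lower number from compound 2 to compound 3 (0.22 log units; within the scatter), which lies within the scatter, so the two compounds cannot be told apart on these data, and compound 3 is not shown to be the stronger of the pair.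

Compound 4 `Cc1ccc(S(=O)(=O)Nc2ccc(C(=O)/C=C/c3ccc([N+](=O)[O-])cc3)cc2)cc1` is the next compound in line. Its difference from compound 3 is nitro in place of bromo on an aromatic carbon. Within the data shown here, the one measured step that bears on this change is the one at the same aromatic carbon, from compound 2 to compound 3 , where a change of substituent moved the number by a 1.6-fold lower number from compound 2 to compound 3 (0.22 log units; within the scatter), not beyond the scatter. Among the measured compounds shown here, no other step on the core is available. On that basis the step expected for compound 4 is a 1.0-fold lower number from compound 3 to compound 4 (0.00 log units; within the scatter), that is, no movement beyond the scatter. The value estimated for compound 4 in this assay is 30000 nM, with a range from 10000 nM to 90000 nM.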

Compound 4, half-maximal inhibitory concentration: 26000 nM
Compound 4: the middle estimate sits 1.2-fold (0.06 log units) above what was measured; the measured number falls inside the stated range.
By their numbers in this assay, from the lowest: compounds 4, 3 and 2 (each within the scatter of the next).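

In this assay, the change from 4-bromophenyl to 4-nitrophenyl gives a 1.2-fold lower number from compound 3 to compound 4 (0.07 log units; within the scatter), and nitro in place of methyl on the same aromatic carbon gives a 1.9-fold lower number from compound 2 to compound 4 (0.28 log units; within the scatter), so methyl, bromo and nitro at this position, para to a large group, cannot be told apart on these numbers. The earlier pair covered only methyl and bromo; nitro adds a group with more heavy atoms and with two hydrogen-bond acceptors where bromo has none, and neither of these differences separates compound 4 from compound 2 or compound 3 in this read-out. No measurement offered here explains why these substituents fall so close together.

Compound 1, which carries no substituent at this position, is recorded as "not active" (no number reported), so its steps to the other compounds cannot be read, and what any of these substituents adds over the unsubstituted ring remains unsettled. Also open, as far as these compounds go, is whether an amine, a carboxylic acid or a longer alkyl chain on this aromatic carbon would give a step beyond the scatter.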